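A few compounds are considered here, and "the series" means these few. Any claim that something is new, unique, unknown or untested is made for them only; others in the source may bear on it.

Compound 1 `CC1CCCN1c1ccc2cc(NC(=O)CCc3ccc(C(F)(F)F)cc3)ccc2n1` in a functional assay on HEK293 cells for activation of melanin-concentrating hormone receptor 1 (Rattus norvegicus), read by inositol phosphate accumulation (on this read-out higher numbers stand for an effect only at larger amounts of compound and lower numbers for an effect already at smaller amounts), gives 270 nM, the highest of the two numbers recorded so far. Compound 2 `O=C(CCCCCCCCCCCCc1ccc(C(F)(F)F)cc1)Nc1ccc2nc([N+]34CCC(CC3)CC4)ccc2c1` in this assay gives 25 nM; the gap to compound 1 lies beyond the scatter, but the two structures differ in several places at once, so no single change can be read from that pair. Compound 3 `O=C(CCc1ccc(C(F)(F)F)cc1)Nc1ccc2nc(N3CCC4(CCNC4)C3)ccc2c1` differs from compound 1 only at the amine on the shared core: a group of 9 heavy atoms (7 carbon, 2 nitrogen; 2 five-membered non-aromatic rings with 1 hetero atom each) in place of a group of 6 heavy atoms (5 carbon, 1 nitrogen; one five-membered non-aromatic ring with 1 hetero atom), on an aromatic carbon. Among the compounds with values here, no measured step covers this change, so only a moderate move toward a lower number is expected, a 1.8-fold lower number from compound 1 to compound 3 (0.26 log units; within the scatter). Compound 3 is expected to give 150 nM, estimated between 40 nM and 600 nM.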

Compound 3, half-maximal effective concentration: 140 nM
Compound 3: the middle estimate sits 1.1-fold (0.03 log units) above what was measured; the measured number falls inside the stated range.
By their numbers in this assay, from the lowest: compound 2; then compounds 3 and 1 (each within the scatter of the next).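

In this assay, replacing 2-methylpyrrolidin-1-yl with the larger two-ring amine at the aromatic carbon next to the ring nitrogen gives a 1.9-fold lower number from compound 1 to compound 3 (0.29 log units; within the scatter) and so shows that this position accepts the added ring and the hydrogen-bond donor without a shift beyond the scatter. No measurement on hand bears on this result.

Still open, as far as these compounds go, is whether morpholine or piperazine at this position would move the number beyond the scatter. Also open, from the compounds shown here alone, is how a carboxylic acid on the two-ring amine of compound 3 would read.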